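A second chlorine on a compound at the assay limit

This account rests on a few compounds, and the source may have more. Where it says the series, first, only, none or still open, it means among the compounds named here.

In a functional assay on U-251 cells (Homo sapiens) for inhibition, read by MTT assay, with a stated time of 2 days (a lower number here means that less compound is tolerated, a higher number that more compound is tolerated), compound 1 (`Nc1ccccc1NC(=O)CCCNCC(=O)Nc1cccc(Cl)c1`) gives > 100000 nM as a limit, not a number. Compound 2 (`Nc1ccccc1NC(=O)CCCNCC(=O)Nc1ccc(Cl)cc1`) also gives > 100000 nM as a limit. Compound 3 (`Nc1ccccc1NC(=O)c1ccc(NCC(=O)Nc2cccc([N+](=O)[O-])c2)cc1`) gives > 100000 nM as a limit too. Compound 1 therefore shares with them the limit of > 100000 nM in this assay, at which 3 of the 3 values shown sit, and has no number of its own. Compound 4 (`Nc1ccccc1NC(=O)CCCNCC(=O)Nc1cc(Cl)ccc1Cl`) differs from compound 1 by one change (chloro in place of hydrogen on an aromatic carbon) that turns 3-chlorophenyl into 2,5-dichlorophenyl. Among the measured compounds shown here, the one measured step that bears on it is a step that the two limits leave unreadable from compound 1 to compound 2 and gives no size to carry over, so no step beyond the scatter is expected in either direction. An estimated a number no higher from compound 1 to compound 4 (the limit leaves the size open) is expected in this assay on this basis. Compound 4 is expected at 100000 nM (estimated range 40000 nM to 250000 nM).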

Compound 4, concentration lethal to 50% of the cells: > 100000 nM
Compound 4 was reported as a limit; the forecaster's own chance of this, stated with the estimate: 80%; the middle value lies on the limit itself.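

No step can be read among compound 1, compound 2 and compound 4, as each value is a limit and not a number: the limit of > 100000 nM in this assay, at which 4 of the 4 values shown sit.

On these data alone, whether the added chloro changes the result, and how these three compounds rank, stays open.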